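Removing Both Fluorines: Expected Cytotoxicity of Compound 3

The source may hold more compounds than are shown below. What is called first, only, known or untested is meant among the compounds shown, and "the series" means these compounds.

Measured so far:
compound 1, `COc1cc(-c2nnc(SCc3ccc(F)cc3F)o2)ccc1O`, 520000 nM in an ADME assay on cells (Mus musculus, strain BALB/c) for cytotoxicity, read by MTT assay, with a stated time of 24 h; a lower number here means that less compound is tolerated, a higher number that more compound is tolerated
compound 2, `COc1cc(-c2nnc(SCc3ccccc3Cl)o2)ccc1O`, 564000 nM in this assay

Going by the values given here, compound 1 stands lowest of the two numbers; compound 2 is its only neighbour, and the step of a 1.1-fold higher number from compound 1 to compound 2 (0.04 log units; within the scatter) shows the two lie within the scatter. Compound 3, `COc1cc(-c2nnc(SCc3ccccc3)o2)ccc1O`, differs from compound 1 as follows: phenyl in place of 2,4-difluorophenyl on a saturated chain carbon bound to a sulfur. Among the compounds with values here, the one measured step bearing on this place in the molecule, a 1.1-fold higher number from compound 1 to compound 2 (0.04 log units; within the scatter), was small, so no step beyond the scatter is expected in this assay. Compound 3 is therefore estimated at 540000 nM, with a range from 300000 nM to 1000000 nM, a step of a 1.0-fold higher number from compound 1 to compound 3 (0.02 log units; within the scatter).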

Compound 3, half-maximal cytotoxic concentration: 211000 nM
Compound 3: the middle estimate sits 2.6-fold (0.41 log units) above what was measured; the measured number lies below the stated range.
By their numbers in this assay, from the lowest: compound 3; then compounds 1 and 2 (each within the scatter of the next).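

In this assay phenyl in place of 2,4-difluorophenyl gives a 2.5-fold lower number from compound 1 to compound 3 (0.39 log units; beyond the scatter) and hydrogen in place of chloro on an aromatic carbon gives a 2.7-fold lower number from compound 2 to compound 3 (0.43 log units; beyond the scatter) (both modest). The ring on this chain carbon therefore does affect the number: compound 1 and compound 2, with different halogens, lie within the scatter of each other, while compound 3, with no halogen, stands apart, with less compound tolerated. Nothing available explains this shift. Still open, going by these compounds, is whether a single fluorine on this ring would match compound 1, and whether a non-halogen group such as methoxy or an amine would behave like the halogens or like hydrogen.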